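Methoxy in Place of Methyl: What to Expect for Compound 4

This account rests on a few compounds, and the source may have more. Where it says the series, first, only, none or still open, it means among the compounds named here.

The series was examined in a functional assay on MOLT-4 cells (Homo sapiens) for antiproliferative activity, read by cell counting, with a stated time of 2 days; on this read-out lower numbers stand for stronger inhibition and higher numbers for weaker inhibition. Compound 1 `Cc1ccc(Nc2nc(-n3ccnc3C)cs2)cc1` gives 510 nM, and compound 2 `Cc1ccc(Nc2nc(N)c(C(=O)c3ccccc3)s2)cc1` gives 210 nM. Compound 3 `COc1cc(C(=O)c2sc(Nc3ccc(C)cc3)nc2N)cc(OC)c1OC` stands lowest of the three, at 21 nM; its nearest neighbour on the numbers is compound 2, and that gap lies beyond the scatter, while the gap to compound 1 is wider still and also beyond the scatter.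

Compound 4 `COc1ccc(Nc2nc(N)c(C(=O)c3cc(OC)c(OC)c(OC)c3)s2)cc1` has not yet been measured in this assay. It differs from compound 3 in one place: methoxy in place of methyl on an aromatic carbon. Among the measured compounds shown here, no pair of measured compounds in this set differs by such a single change, so there is no measured step to lean on. The change adds one hydrogen-bond acceptor and one heavy atom on an aromatic carbon, and nothing in the three measured compounds points to a direction for it.

Compound 4 is therefore expected to stay close to compound 3, with a step of a 1.2-fold higher number from compound 3 to compound 4 (0.08 log units; within the scatter) that should not exceed the scatter. The estimate for compound 4 in this assay is 25 nM, within a range from 8 nM to 80 nM.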

Compound 4, half-maximal inhibitory concentration: 480 nM
The estimate for compound 4 lay 19-fold (1.28 log units) below the measured number; the measured number lies above the stated range.
By their numbers in this assay, from the lowest: compound 3; then compound 2; then compounds 4 and 1 (each within the scatter of the next).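

In this assay, among the compounds shown here, this pair gives the first measured single change, and replacing 4-methylphenyl with 4-methoxyphenyl produces a 23-fold higher number from compound 3 to compound 4 (1.36 log units; beyond the scatter). The place on the aromatic ring, para to a large group, is therefore sensitive to this substitution, even though the change adds only one heavy atom and one hydrogen-bond acceptor. Nothing measured here accounts for the loss.

With only methyl and methoxy at this place, the compounds shown cannot separate the effect of the oxygen from that of the added heavy atom, and an ethyl group or a chlorine atom there would help to tell these apart. They also leave open whether the same change would produce a similar step on the core of compound 1.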